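This account rests on a few compounds, and the source may have more. Where it says the series, first, only, none or still open, it means among the compounds named here.

In an assay on CHO cells with 5-hydroxytryptamine receptor 1B (Homo sapiens) as the target (on this read-out lower numbers stand for stronger inhibition and higher numbers for weaker inhibition), compound 1 `CN(CC1CC1)CC1(O)CCN(CCCc2c[nH]c3ccc(-n4cnnc4)cc23)CC1` gives 27 nM, compound 2 `OC1(CNCc2ccccc2)CCN(CCCc2c[nH]c3ccc(-n4cnnc4)cc23)CC1` gives 47 nM, and compound 3 `Cc1ccccc1CNCC1(O)CCN(CCCc2c[nH]c3ccc(-n4cnnc4)cc23)CC1` gives 83 nM. Compound 3 stands highest of the three, though its gap to compound 2 is within the scatter, as shown by a 1.8-fold higher number from compound 2 to compound 3 (0.25 log units; within the scatter); only the gap to compound 1, a 3.1-fold higher number from compound 1 to compound 3 (0.49 log units; beyond the scatter), reaches beyond it. Compound 4 `CC(C)(C)OC(=O)NCC1(O)CCN(CCCc2c[nH]c3ccc(-n4cnnc4)cc23)CC1` differs from compound 3 by tert-butoxycarbonyl in place of 2-methylbenzyl on an amine nitrogen. The measured steps that touch the same amine nitrogen are a 1.7-fold higher number from compound 1 to compound 2 (0.24 log units; within the scatter) and a 3.1-fold higher number from compound 1 to compound 3 (0.49 log units; beyond the scatter), both small, and a 1.8-fold higher number from compound 2 to compound 3 (0.25 log units; within the scatter), which changes only a methyl on an aromatic carbon. For the measured compounds named here, none of them exchanges the group on that nitrogen for a tert-butoxycarbonyl, so no step in this set covers the change directly. Given that every variation at this position so far has moved the number only modestly, compound 4 is expected to land somewhat higher than compound 3, by about a 3.0-fold higher number from compound 3 to compound 4 (0.48 log units; beyond the scatter), with wide uncertainty. Compound 4 is therefore estimated in this assay at 250 nM, within a range of 60 nM to 1200 nM.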

Compound 4, half-maximal inhibitory concentration: 340 nM
The estimate for compound 4 lay 1.4-fold (0.13 log units) below the measured number, within the range that was stated.
By their numbers in this assay, from the lowest: compounds 1, 2 and 3 (each within the scatter of the next, the first and the last beyond it); then compound 4.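

Earlier exchanges on this amine nitrogen, all among groups of carbon only, had stayed modest, and the first group carrying oxygen goes further. In this assay, tert-butoxycarbonyl, with no ring and two hydrogen-bond acceptors where 2-methylbenzyl has none, gives a 4.1-fold higher number from compound 3 to compound 4 (0.61 log units; beyond the scatter), and against the other two amines the change reads a 7.2-fold higher number from compound 2 to compound 4 (0.86 log units; beyond the scatter) and a 13-fold higher number from compound 1 to compound 4 (1.10 log units; beyond the scatter), which makes compound 4 the weakest of the four. No supporting data are available to explain this shift.

The loss of the aromatic ring and the arrival of the carbonyl come together in compound 4, so the compounds shown do not separate them. As far as these compounds go, how an acetyl group, a plain tert-butyl group or the free primary amine on that nitrogen would read remains open.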